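Extending the alkyl chain of the amide aryl ring

This account rests on a few compounds, and the source may have more. Where it says the series, first, only, none or still open, it means among the compounds named here.

Measured compounds:
- compound 1, `O=C(Nc1cccc(-c2oc3cc(-c4ccc(F)cc4)ccc3c(=O)c2O)c1)c1ccc(F)cc1`: 14200 nM
- compound 2, `COc1ccc(C(=O)Nc2cccc(-c3oc4cc(-c5ccc(F)cc5)ccc4c(=O)c3O)c2)cc1`: 5490 nM
- compound 3, `CCc1ccc(C(=O)Nc2cccc(-c3oc4cc(-c5ccc(F)cc5)ccc4c(=O)c3O)c2)cc1`: 13200 nM

All three compounds were tested in a functional assay on HCC1937 cells (Homo sapiens) for antiproliferative activity, read by CCK-8 assay, with a stated time of 72 h; on this read-out lower numbers stand for stronger inhibition and higher numbers for weaker inhibition. Among the compounds with values here, compound 3 stands second highest of the three numbers: its nearest neighbour is compound 1, at a 1.1-fold lower number from compound 1 to compound 3 (0.03 log units; within the scatter), while the only clearly separated value is that of compound 2, with a 2.4-fold higher number from compound 2 to compound 3 (0.38 log units; beyond the scatter). Compound 4, `CCCc1ccc(C(=O)Nc2cccc(-c3oc4cc(-c5ccc(F)cc5)ccc4c(=O)c3O)c2)cc1`, differs from compound 3 by methyl in place of hydrogen on a saturated chain carbon, two bonds along the chain from an aromatic carbon.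

Within the data shown here, no measured step changes the length of this chain, so the closest guidance is indirect. The two steps that touch the same aromatic carbon, a 1.1-fold lower number from compound 1 to compound 3 (0.03 log units; within the scatter) and a 2.6-fold lower number from compound 1 to compound 2 (0.41 log units; beyond the scatter), show that swapping one small group for another at this position moves the number only modestly at most. Adding one carbon to an existing chain is a smaller change than either of those swaps, so the step of a 1.1-fold lower number from compound 3 to compound 4 (0.04 log units; within the scatter) is expected to fall within the scatter, with no clear direction. Compound 4 is therefore estimated at 12000 nM, with a range from 4000 nM to 36000 nM.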

Compound 4, half-maximal inhibitory concentration: 15400 nM
Compound 4: middle estimate off by 1.3-fold (0.11 log units), on the low side; the measured number falls inside the stated range.
By their numbers in this assay, from the lowest: compound 2; then compounds 3, 1 and 4 (each within the scatter of the next).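

In this assay, the one chain extension here, from ethyl to propyl, leaves the number within the scatter (a 1.2-fold higher number from compound 3 to compound 4 (0.07 log units; within the scatter)). Propyl also cannot be told apart from fluoro on this aromatic carbon (a 1.1-fold higher number from compound 1 to compound 4 (0.04 log units; within the scatter)), whereas methoxy stays the only group of the four that separates from the others, now also from propyl (a 2.8-fold higher number from compound 2 to compound 4 (0.45 log units; beyond the scatter)). Nothing available accounts for either the flat response to chain length or the separate place of methoxy.

On these data alone, it remains open whether a longer chain such as butyl, a branched group such as isopropyl, or an amine on this aromatic carbon would move the number beyond the scatter. As far as these compounds go, it is also open whether ethoxy would keep the lower number seen with the methoxy of compound 2.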